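A few compounds are considered here, and "the series" means these few. Any claim that something is new, unique, unknown or untested is made for them only; others in the source may bear on it.

Compound 1 `CN1C(=O)/C(=C/N2N=C(c3ccccc3)CC2c2ccccc2O)SC1=S` is the reference point: in a functional assay on SK-OV-3 cells (Homo sapiens) for antiproliferative activity, read by MTT assay, with a stated time of 72 h (a higher number here means a weaker inhibitor, a lower number a stronger inhibitor), compound 1 gives 341 nM. Compound 2 `O=C1/C(=C/N2N=C(c3ccccc3)CC2c2ccccc2O)SC(=S)N1c1cccc(C(F)(F)F)c1` carries a 3-(trifluoromethyl)phenyl group on the same ring nitrogen that holds a methyl in compound 1. For compound 2 this assay reports only a limit, > 10000 nM, so its true value is not a number but the edge of the measurement, as noted in the limit of > 10000 nM in this assay, at which 1 of the 2 values shown sits. Going by the values given here, the one measured step, an at least 29-fold higher number from compound 1 to compound 2 (1.46 log units; beyond the scatter), is therefore large and points toward weaker inhibition when the aryl group replaces the methyl. Compound 3 `CCOC(=O)CCN1C(=O)/C(=C/N2N=C(c3ccccc3)CC2c2ccccc2O)SC1=S` differs from compound 2 in one place: 2-(ethoxycarbonyl)ethyl in place of 3-(trifluoromethyl)phenyl on an amide-type nitrogen in a ring. This change removes the group that accompanied the large loss and installs a short flexible chain with no ring, closer in kind to the methyl of compound 1. Compound 3 is therefore expected to show a step back toward stronger inhibition, an at least 11-fold lower number from compound 2 to compound 3 (1.04 log units; beyond the scatter), though the size of that return is uncertain since compound 2 sits only at a limit. The estimate for compound 3 in this assay is 900 nM, with a plausible range from 200 nM to 5000 nM.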

Compound 3, half-maximal inhibitory concentration: > 10000 nM
Compound 3 was reported as a limit; the forecaster's own chance of this, stated with the estimate: 20%; middle value at least 11-fold (1.04 log units) away from the limit.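

The large step away from methyl, an at least 29-fold higher number from compound 1 to compound 3 (1.46 log units; beyond the scatter), now comes from a flexible chain with no ring, 2-(ethoxycarbonyl)ethyl. The loss in this assay therefore does not depend on the aromatic ring of compound 2, and among the compounds shown, methyl is the only group on this ring nitrogen that gives a measurable value. The step between compound 2 and compound 3 cannot be read, and neither compound can be ranked above the other: the limit of > 10000 nM in this assay, at which 2 of the 3 values shown sit.

From the compounds shown here alone, what an ethyl group, a plain hydrogen or a free carboxylic acid on this nitrogen would give stays open. It is also unknown how small a change from methyl is enough to lose the activity.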